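Fluoro added to the aryl ring of compound 1

The source may report more compounds than this note shows. Statements on the series, on what has been measured and on what is new or still open speak of the compounds shown alone.

Measured compounds in a functional assay on KB cells (Homo sapiens) for antiproliferative activity, read by sulforhodamine B assay, with a stated time of 3 days; on this read-out lower numbers stand for an effect already at smaller amounts and higher numbers for an effect only at larger amounts of compound:
compound 1, `CCC1=C(O)c2c(oc(-c3cccc(C)c3)cc2=O)C(CC)(CC)C1=O`, 49.7 uM
compound 2, `CCC1=C(O)c2c(oc(-c3cccc(OC(F)(F)F)c3)cc2=O)C(CC)(CC)C1=O`, a limit of the assay, > 47.4 uM
compound 3, `CCC1=C(O)c2c(oc(-c3cc(C)c(OC)cc3C)cc2=O)C(CC)(CC)C1=O`, 36.6 uM

Among the two numbers given, compound 1 holds the higher one, but its gap to compound 3 lies within the scatter of repeated measurements, so no order between the two can be read. For compound 2 the assay reports only a limit, > 47.4 uM. The step that the limit leaves unreadable from compound 1 to compound 2 is therefore unreadable, its size unknown, because of the limit of > 47.4 uM in this assay, at which 1 of the 3 values shown sits.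

Compound 4, `CCC1=C(O)c2c(oc(-c3cc(C)ccc3F)cc2=O)C(CC)(CC)C1=O`, is not yet measured. Against compound 1 the change is fluoro in place of hydrogen on an aromatic carbon. Going by the values given here, no measured step in this set alters the same ring in the same way: the only step from compound 1 ends at a limit, and compound 3 changes the ring in several places at once. With no readable reference, the step in this assay is expected to stay within the scatter, a 1.1-fold lower number from compound 1 to compound 4 (0.04 log units; within the scatter). Compound 4 is therefore estimated at 45 uM, between 20 uM and 100 uM.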

Compound 4, concentration for half-maximal effect: 47.3 uM
Estimate against measurement, compound 4: 1.1-fold (0.02 log units) below; low and high end bracket the measured number.
By their numbers in this assay, from the lowest: compounds 3, 4 and 1 (each within the scatter of the next).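

In this assay, fluoro in place of hydrogen on an aromatic carbon, ortho to a large group and para to a methyl group, gives a 1.1-fold lower number from compound 1 to compound 4 (0.02 log units; within the scatter). Going by these compounds alone, this is the first single change on the aryl ring of compound 1 that can be read as a step, and it shows that fluoro at this position leaves the number within the scatter. Compound 1 and compound 4 therefore cannot be put in order, and the change from 3-methylphenyl to 2-fluoro-5-methylphenyl gives no handle on the read-out here.

Going by these compounds, whether an amine or a carboxylic acid at this same position would move the number beyond the scatter in this assay remains open. The value of compound 2 is a limit, and the step to it cannot be read: the limit of > 47.4 uM in this assay, at which 1 of the 4 values shown sits.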